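Replacing the hydroxy of compound 3 with a boron-bearing group

This account rests on a few compounds, and the source may have more. Where it says the series, first, only, none or still open, it means among the compounds named here.

In a functional assay on MCF7 cells (Homo sapiens) for antiproliferative activity, read by sulforhodamine B assay, with a stated time of 48 h (a lower number here means a stronger inhibitor, a higher number a weaker inhibitor), compound 1 `COc1ccc(/C=C/C(=O)c2ccccc2-c2ccc(F)cc2)cc1` gives 670 nM and compound 2 `COc1ccc(/C=C/C(=O)c2ccccc2-c2ccc(F)cc2)cc1OC` gives 240 nM while compound 3 `COc1ccc(/C=C/C(=O)c2ccccc2-c2ccc(F)cc2)cc1O` gives 190 nM in the same test. Compound 3 thus lies within the scatter of compound 2 (a 1.3-fold lower number from compound 2 to compound 3 (0.10 log units; within the scatter)) and clear of compound 1 (a 3.5-fold lower number from compound 1 to compound 3 (0.55 log units; beyond the scatter)). Compound 4 `COc1ccc(/C=C/C(=O)c2ccccc2-c2ccc(F)cc2)cc1B(O)O` differs from compound 3 by one change: a group of 3 heavy atoms (1 boron, 2 oxygen; no ring) in place of one oxygen atom, on an aromatic carbon on an aromatic carbon, ortho to a methoxy group and meta to a large group. Methoxy at that carbon gave a modest step (a 2.8-fold lower number from compound 1 to compound 2 (0.45 log units; beyond the scatter)), and exchanging it for hydroxy stayed within the scatter. Among the measured compounds shown here, no measured compound carries boron, so the expectation stays loose. The expected step (a 1.3-fold higher number from compound 3 to compound 4 (0.12 log units; within the scatter)) lies within the scatter. For compound 4 the estimate is 250 nM and the expected range runs from 70 nM to 900 nM in this test.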

Compound 4, half-maximal inhibitory concentration: 220 nM
Compound 4: the middle estimate sits 1.1-fold (0.06 log units) above what was measured; measured number inside the range.
By their numbers in this assay, from the lowest: compounds 3, 4 and 2 (each within the scatter of the next); then compound 1.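

In this assay, the boron-bearing group on this aromatic carbon, ortho to a methoxy group, cannot be told apart from hydroxy (a 1.2-fold higher number from compound 3 to compound 4 (0.06 log units; within the scatter)) or from methoxy (a 1.1-fold lower number from compound 2 to compound 4 (0.04 log units; within the scatter)). It also stands clear of hydrogen (a 3.0-fold lower number from compound 1 to compound 4 (0.48 log units; beyond the scatter)), so three different groups at this position now separate from hydrogen but not from one another. No measurement at hand explains this result. The compounds shown leave open whether an amine or a carboxylic acid on this carbon would join those three groups or fall back towards hydrogen.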